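Extending the chain on the cyclic isothiourea inhibitor

A few compounds are considered here, and "the series" means these few. Any claim that something is new, unique, unknown or untested is made for them only; others in the source may bear on it.

Measured compounds:
- compound 1, `CCCCCCCCNC(=S)N1[C@H](CO)[C@@H](O)[C@H](O)[C@H]1CO`: 414000 nM
- compound 2, `CCCCCCCCCC/N=C1/SC[C@@H]2[C@@H](O)[C@H](O)[C@@H](CO)N12`: 93000 nM
- compound 3, `CCCC/N=C1/SC[C@H]2[C@H](O)[C@@H](O)[C@H](CO)N12`: 719000 nM

In an assay for inhibition of beta-galactosidase (Bos taurus), read by spectrophotometry (on this read-out lower numbers stand for stronger inhibition and higher numbers for weaker inhibition), compound 2 gives the lowest number of the three. Compound 1, an open thiourea with a shorter chain, gives 414000 nM in this assay, a number beyond the scatter above that of compound 2. Compound 3, the mirror-image core with a shorter chain, gives 719000 nM in this assay, also beyond the scatter and furthest from compound 2. On these three compounds alone, the longer chain sits with the lower number, though the cores also differ, so no firm pattern can be drawn.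

Compound 4, `CCCCCCCCCCCC/N=C1/SC[C@@H]2[C@@H](O)[C@H](O)[C@@H](CO)N12`, takes this further. The change from compound 2 is ethyl in place of hydrogen on a saturated chain carbon, ten or more bonds along the chain from a double-bonded nitrogen. Within the data shown here, no measured pair shows this exact step, so the expectation rests only on the direction seen so far. A modest step toward a lower number seems most likely for compound 4, with a real chance of no change beyond the scatter; the estimated step is a 1.9-fold lower number from compound 2 to compound 4 (0.27 log units; within the scatter). In this assay compound 4 is therefore expected to give about 50000 nM, within a range from 15000 nM to 200000 nM.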

Compound 4, half-maximal inhibitory concentration: 32000 nM
The estimate for compound 4 lay 1.6-fold (0.19 log units) above the measured number; the range from low to high includes it.
By their numbers in this assay, from the lowest: compound 4; then compound 2; then compounds 1 and 3 (each within the scatter of the next).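

In this assay, among these compounds, ethyl in place of hydrogen on a saturated chain carbon, ten or more bonds along the chain from a double-bonded nitrogen, gives a 2.9-fold lower number from compound 2 to compound 4 (0.46 log units; beyond the scatter) and is the first comparison here in which the core stays the same and only the chain changes. Among the compounds shown here, this shows that, this far along the chain, adding a group of only 2 carbon atoms, with no ring, no charge and no hydrogen-bond donors or acceptors, can move the number beyond the usual scatter, something the earlier compounds, whose cores also differ, could not show. Nothing at hand explains why the longer chain goes with the lower number.

As far as these compounds go, a single step gives a direction in one place only, so it remains open whether a still longer chain would keep lowering the number, level off or reverse the change. Also open, from the compounds shown here alone, are whether the same step would hold on the mirror-image core of compound 3, and whether a chain ending in an amine or a carboxylic acid would follow the same direction.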